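A few compounds are considered here, and "the series" means these few. Any claim that something is new, unique, unknown or untested is made for them only; others in the source may bear on it.

Compound 2 `CC(C)C[C@H](N)c1cc(C(F)(F)F)ccc1N1CCN(C(=O)COc2ccc(Cl)cc2)CC1` is the weaker of the two measured compounds in an assay on HEK293 cells for displacement of a labelled ligand from Melanocortin receptor 4 (Homo sapiens); on this read-out higher numbers stand for weaker inhibition and lower numbers for stronger inhibition: compound 2 gives 2900 nM, whereas compound 1 `CC(C)C[C@H](N)c1cc(C(F)(F)F)ccc1N1CCN(C(=O)CC(C)C(=O)c2ccc(Cl)cc2)CC1` gives 1100 nM. Going by the values given here, the one measured step, a 2.6-fold higher number from compound 1 to compound 2 (0.42 log units; beyond the scatter), concerns the replacement of 1-((4-chlorophenyl)carbonyl)ethyl by 4-chlorophenoxy on the saturated chain carbon bound to the carbonyl carbon, and it moved the number up by a modest amount.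

Compound 3 `CC(C)C[C@H](N)c1cc(C(F)(F)F)ccc1N1CCN(C(=O)COc2cccc(Cl)c2Cl)CC1` keeps the phenoxy link of compound 2 and alters only the ring on it: 2,3-dichlorophenyl in place of 4-chlorophenyl on an oxygen on a saturated carbon. Among the compounds with values here, no measured step bears on this change; the step from compound 1 to compound 2 concerns a different part of the molecule, and nothing measured shows how the halogen pattern on the aryl ring on the oxygen affects this assay. With no guide from the data, the change is expected to give at most a small shift in this assay, within or close to the scatter, in either direction, so that a 1.2-fold lower number from compound 2 to compound 3 (0.06 log units; within the scatter) is the expected step. Compound 3 is therefore estimated at 2500 nM, with a range from 800 nM to 8000 nM.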

Compound 3, inhibition constant: 2500 nM
For compound 3 middle estimate and measured number coincide at the digits printed, and the stated range covers the measured number.
By their numbers in this assay, from the lowest: compound 1; then compounds 3 and 2 (each within the scatter of the next).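

In this assay, the ring on the oxygen proved to be a place where adding a second chlorine and going from 4-chlorophenyl to 2,3-dichlorophenyl left the number unresolved from its parent, with a 1.2-fold lower number from compound 2 to compound 3 (0.06 log units; within the scatter), so the two chlorine patterns cannot be told apart on this read-out. The difference from the side chain of compound 1 remains with the new ring: alongside a 2.6-fold higher number from compound 1 to compound 2 (0.42 log units; beyond the scatter) there now stands a 2.3-fold higher number from compound 1 to compound 3 (0.36 log units; beyond the scatter), so both phenoxy compounds give higher numbers than compound 1, by a modest amount and beyond the scatter, and neither chlorine pattern closes that gap. No independent evidence accounts for either the flat step on the ring or the gap to compound 1.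

The compounds shown leave open whether a different kind of group on this ring, such as a methoxy group, a nitrile or an amine, would move the number beyond the scatter. They also leave open whether 2,3-dichlorophenyl would behave the same way on the carbonyl of the side chain of compound 1, and what a longer chain in place of the saturated chain carbon bound to the carbonyl carbon would do.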